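The source may report more compounds than this note shows. Statements on the series, on what has been measured and on what is new or still open speak of the compounds shown alone.

Compound 2 `COc1ccc(Nc2nc(SCc3ccc(C(F)(F)F)cc3)nc3ccccc23)cc1` is one of two members of a small series tested in a functional assay on MCF7 cells (Homo sapiens) for cytotoxicity, read by MTT assay, with a stated time of 72 h (on this read-out lower numbers stand for stronger inhibition and higher numbers for weaker inhibition), where compound 2 gives 47200 nM, the higher of the two numbers. Among the measured compounds shown here, its nearest neighbour is compound 1 `CCCCCCCCNc1nc(SCc2ccc(C(F)(F)F)cc2)nc2ccccc12`, which in this assay gives 26100 nM; the only measured step, a 1.8-fold higher number from compound 1 to compound 2 (0.26 log units; within the scatter), lies within the scatter of repeat measurements.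

Compound 3 `COc1ccc(Nc2nc(SCc3ccc(C(F)(F)F)cc3)nc3ccccc23)c(OC)c1` has not yet been measured. It differs from compound 2 by a single change: methoxy in place of hydrogen on an aromatic carbon. This second methoxy sits on an aromatic carbon of a six-membered aromatic ring of carbon only, ortho to a large group and meta to a methoxy group.

For the measured compounds named here, no measured step in this set touches this position, so the only guidance is that the sole measured change, a 1.8-fold higher number from compound 1 to compound 2 (0.26 log units; within the scatter), moved the number by less than the scatter despite being a much larger structural swap. On that basis the step from compound 2 to compound 3 is expected to be small, with no direction supported beyond the scatter, that is a 1.1-fold lower number from compound 2 to compound 3 (0.05 log units; within the scatter). Compound 3 is therefore estimated at 42000 nM in this assay, with a plausible range from 15000 nM to 120000 nM.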

Compound 3, half-maximal inhibitory concentration: > 50000 nM
Compound 3 was reported as a limit; the forecaster's own chance of this, stated with the estimate: 10%; middle value at least 1.1-fold (0.07 log units) away from the limit.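

In this assay compound 3 is reported only as a limit, > 50000 nM, and not as a number, the one value of this kind in the series: the limit of > 50000 nM in this assay, at which 1 of the 3 values shown sits.

The methoxy added on the aromatic carbon ortho to a large group and meta to a methoxy group gives an at least 1.0-fold higher number from compound 2 to compound 3 (0.02 log units; that floor lies within the scatter), and 2,4-dimethoxyphenyl in place of octyl gives an at least 1.9-fold higher number from compound 1 to compound 3 (0.28 log units; that floor lies within the scatter). Both steps are floors that lie within the scatter, so they fix a direction only as a lower bound on the number and leave the true size of each change unknown. Among the compounds shown here, what this adds to the earlier compounds is a first reading at this position, and it shows that this second methoxy brought no gain in inhibition on these cells.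

The compounds shown do not tell how far the number of compound 3 lies past its limit, nor whether the same position would respond differently to a hydroxyl, a fluorine or an amine. They also leave open whether a methoxy on this carbon would behave the same way in a 2-methoxyphenyl group, without the methoxy already present in compound 2.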